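The compounds below may be only part of what the source reports. "The series", "measured", "known", "first", "only" and "open" are said of these compounds alone.

Measured compounds:
compound 1, `CC(C)n1nc(C(=O)N[C@H]2COc3ccccc3N(C)C2=S)nc1Cc1ccccc1`: > 100000 nM
compound 2, `CN1C(=S)[C@@H](NC(=O)c2nc(Cc3ccccc3)n(CCCCCC#N)n2)COc2ccccc21`: > 100000 nM

Compound 2 stands at a limit in a toxicity assay on HT-29 cells (Homo sapiens) for cytotoxicity; a higher number here means that more compound is tolerated, a lower number that less compound is tolerated. In this assay compound 2 gives > 100000 nM, which is a limit of the assay and not a number. Compound 1 gives > 100000 nM in this assay, again a limit. Among the compounds with values here, the one measured step, a step that the two limits leave unreadable from compound 1 to compound 2, therefore cannot be read, since (the limit of > 100000 nM in this assay, at which 2 of the 2 values shown sit).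

Compound 3, `CN1C(=S)[C@@H](NC(=O)c2nc(Cc3ccccc3)n(CC3CCOCC3)n2)COc2ccccc21`, differs from compound 2 by oxan-4-yl in place of 4-cyanobutyl on a saturated chain carbon bound to an aromatic nitrogen. Within the data shown here, no measured step bears on this change directly; the only step between measured compounds, a step that the two limits leave unreadable from compound 1 to compound 2, is unreadable, and both of its end points sit at the limit. The account thus rests on the two limits alone, and the expected step that the limit leaves unreadable from compound 2 to compound 3 is none beyond the scatter, with compound 3 most likely to sit at the limit as well. Compound 3 is estimated at 150000 nM in this assay, within a range from 50000 nM to 500000 nM.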

Compound 3, half-maximal cytotoxic concentration: > 100000 nM
Compound 3: only a limit was reported; the forecaster's own chance of this, stated with the estimate: 85%; the middle value does not contradict the limit.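

In this assay compound 3 gives > 100000 nM, which is a limit of the assay and not a number. Its steps from compound 1 and compound 2 therefore cannot be read: the limit of > 100000 nM in this assay, at which 3 of the 3 values shown sit.

The compounds shown leave open whether isopropyl, 5-cyanopentyl and (oxan-4-yl)methyl differ at all in this assay.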